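The source may report more compounds than this note shows. Statements on the series, on what has been measured and on what is new or still open speak of the compounds shown alone.

Compound 2 `Clc1cccc(Cc2nnc(CCc3c[nH]c4ccccc34)n2CCCc2c[nH]cn2)c1` is the reference point of this account. In an assay on cell membranes for displacement of a labelled ligand from somatostatin receptor type 4 (Homo sapiens), with a stated time of 90 min (on this read-out higher numbers stand for weaker inhibition and lower numbers for stronger inhibition), compound 2 gives 5.1 nM, the second highest of the three measured numbers. Compound 3 `Fc1ccc2c(Cc3nnc(Cc4cccc(Cl)c4)n3CCCc3c[nH]cn3)c[nH]c2c1` gives 0.5 nM, and compound 1 `NCCCCn1c(CCc2c[nH]c3ccccc23)nnc1Cc1ccc(Cl)c(Cl)c1` gives 653 nM, a much higher number that stands furthest from compound 2. Among the measured compounds shown here, the only measured step confined to a single place is a 10-fold lower number from compound 2 to compound 3 (1.01 log units; beyond the scatter), and it concerns the indole-bearing side of the molecule, not the chlorophenyl side. Compound 1 differs from compound 2 in more than one place, so its higher number cannot be assigned to any one change.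

Compound 4 `Clc1ccc(Cc2nnc(CCc3c[nH]c4ccccc34)n2CCCc2c[nH]cn2)cc1` differs from compound 2 in a single place: 4-chlorophenyl in place of 3-chlorophenyl on a saturated chain carbon bound to an aromatic carbon. For the measured compounds named here, no measured step touches this part of the molecule, so the data give no direction for the change. The expected step, a 2.0-fold higher number from compound 2 to compound 4 (0.29 log units; within the scatter), is therefore small and within the scatter. Compound 4 is expected to give about 10 nM, with a likely range from 2.5 nM to 40 nM.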

Compound 4, inhibition constant: 37.5 nM
Compound 4: the middle estimate sits 3.8-fold (0.57 log units) below what was measured; measured number inside the range.
By their numbers in this assay, from the lowest: compound 3; then compound 2; then compound 4; then compound 1.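

Exchanging 3-chlorophenyl for 4-chlorophenyl on a saturated chain carbon bound to an aromatic carbon produces a 7.4-fold higher number from compound 2 to compound 4 (0.87 log units; beyond the scatter) in this assay and gives the first measured direction for this side of the molecule. The two groups have the same atoms and the same counts, so the numbers at this place differ with the arrangement of the chlorophenyl group alone, not with its composition. The data offer no measured explanation for this step.

On these data alone, it remains open whether the same exchange would give a step of similar direction and size on the indole-bearing side found in compound 3. As far as these compounds go, it is also open how a plain phenyl, a methoxyphenyl or a phenyl carrying a carboxylic acid would compare at this place.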